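The source may hold more compounds than are shown below. What is called first, only, known or untested is meant among the compounds shown, and "the series" means these compounds.

In a functional assay on HCT-116 cells (Homo sapiens) for inhibition, read by sulforhodamine B assay, with a stated time of 48 h, tested at 10 uM (a lower number here means less inhibition of growth, a higher number more inhibition of growth at the concentration tested), compound 1 `CC(=O)c1ccc(NC(=O)Cn2nc(-c3ccc(Cl)cc3)nc2N)cc1` gives 4.68%, and compound 3 `C/C(=N/O)c1ccc(NC(=O)Cn2nc(C(F)(F)F)nc2N)cc1` gives 8.65%. Compound 2 `COc1ccc(-c2nc3sc(-c4ccccc4)cn3n2)cc1` stands highest of the three at 60%, and its gaps to both other compounds lie beyond the usual scatter. Compound 4 `c1ccc(-c2nc3sc(-c4ccccc4)cn3n2)cc1` has yet to be measured. It keeps the core of compound 2 but has hydrogen in place of methoxy on an aromatic carbon, para to a large group: hydrogen in place of methoxy on an aromatic carbon. For the measured compounds named here, no pair of measured compounds isolates this change, so the data offer no direct precedent for its size or direction. The expectation therefore starts from compound 2 at 60% and allows for a modest fall in this assay, although a change within the scatter would not be surprising. The estimated step is a number 12 percentage points lower from compound 2 to compound 4 (beyond the scatter). For compound 4, the expected value is 48%, with an estimated range from 25% to 68%.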

Compound 4, percent growth inhibition at one concentration: 11%
Compound 4: middle estimate off by 37 percentage points, on the high side; the measured number lies below the stated range.
By their numbers in this assay, from the lowest: compounds 1, 3 and 4 (each within the scatter of the next); then compound 2.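

In this assay, for the compounds shown here, the pair of compound 2 and compound 4 is the first to isolate a single change, and it shows that this position on the shared core is far from indifferent. Hydrogen in place of methoxy on an aromatic carbon, para to a large group, gives a number 49 percentage points lower from compound 2 to compound 4 (beyond the scatter), a large step. Nothing measured here accounts for the size of that step.

With only methoxy and hydrogen compared at this place, the compounds shown leave open whether another group there, such as a hydroxyl, an ethoxy or an amine, would keep growth inhibition near that of compound 2 at 60%. They also leave open whether the same change would produce a step of similar size on a different core.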